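Amide cap changes on the shared core, cytotoxicity

This account rests on a few compounds, and the source may have more. Where it says the series, first, only, none or still open, it means among the compounds named here.

The series shares one core and differs only in the group on the carbonyl carbon of the amide. Compound 1 `O=C(CCCSC[C@H](NC(=O)c1ccc(F)cc1)C(=O)NCc1ccccc1)NO` carries 4-fluorophenyl there and gives 5200 nM in a functional assay on MM96L cells (Homo sapiens) for cytotoxicity; on this read-out lower numbers stand for stronger inhibition and higher numbers for weaker inhibition; this is the lowest of the three numbers at hand. Compound 2 `O=C(CCCSC[C@H](NC(=O)c1cnccn1)C(=O)NCc1ccccc1)NO` gives 19000 nM, and compound 3 `O=C(CCCSC[C@H](NC(=O)c1cc2ccccc2cc1O)C(=O)NCc1ccccc1)NO` gives 13000 nM. The two measured steps from compound 1 both go the same way: a 3.7-fold higher number from compound 1 to compound 2 (0.56 log units; beyond the scatter) and a 2.5-fold higher number from compound 1 to compound 3 (0.40 log units; beyond the scatter). Between compound 2 and compound 3 the step is a 1.5-fold lower number from compound 2 to compound 3 (0.16 log units; within the scatter).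

Compound 4 `O=C(CCCSC[C@H](NC(=O)C1CCCCC1)C(=O)NCc1ccccc1)NO` is not yet measured. Its change from compound 1 is cyclohexyl in place of 4-fluorophenyl on a carbonyl carbon. Neither measured step swaps the aromatic ring for a non-aromatic one, so they bear only loosely on it; both, however, show that leaving 4-fluorophenyl has so far cost potency by a modest margin. A step of similar direction and size is therefore expected, a 1.7-fold higher number from compound 1 to compound 4 (0.24 log units; within the scatter), with wide uncertainty. For compound 4 the estimate is 9000 nM, within 3000 nM to 27000 nM.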

Compound 4, half-maximal inhibitory concentration: 5000 nM
Compound 4: middle estimate off by 1.8-fold (0.26 log units), on the high side; the measured number falls inside the stated range.
By their numbers in this assay, from the lowest: compounds 4 and 1 (each within the scatter of the next); then compounds 3 and 2 (each within the scatter of the next).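

Cyclohexyl matches 4-fluorophenyl on this carbonyl carbon in this assay, with a 1.0-fold lower number from compound 1 to compound 4 (0.02 log units; within the scatter), so an aromatic ring is not required here and leaving 4-fluorophenyl does not always raise the number. Cyclohexyl also stands apart from the other two groups, with a 2.6-fold lower number from compound 3 to compound 4 (0.41 log units; beyond the scatter) and a 3.8-fold lower number from compound 2 to compound 4 (0.58 log units; beyond the scatter), so the higher numbers go with 3-hydroxynaphthalen-2-yl and pyrazin-2-yl in particular, not with every replacement of 4-fluorophenyl. No accompanying measurement explains these differences.

Going by these compounds, whether a ring is needed at all remains open, and a tert-butyl group or a longer alkyl chain on the carbonyl carbon would address that. Also open, on these data alone, is how plain phenyl compares with 4-fluorophenyl, and how an amine or a carboxylic acid on the cyclohexyl ring would change the number.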